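The compounds below may be only part of what the source reports. "The series", "measured", "known", "first", "only" and "open" are said of these compounds alone.

Compound 1, `CCCCCNc1ncnc2c1ncn2[C@@H]1O[C@H](CO)[C@@H](O)[C@H]1O`, is the starting point of this account. Within the data shown here, in an assay on isolated protein for binding affinity to Equilibrative nucleoside transporter 1 (Homo sapiens) (on this read-out higher numbers stand for weaker inhibition and lower numbers for stronger inhibition), compound 1 gives 13500 nM, the lowest of the two numbers known so far. Its only measured companion, compound 2, `Nc1ncnc2c1ncn2[C@@H]1O[C@H](COCCOCCNc2ncnc3c2ncn3[C@@H]2O[C@H](CO)[C@@H](O)[C@H]2O)[C@@H](O)[C@H]1O`, gives 912000 nM in this assay, a far higher number, and that gap lies well beyond the scatter of the measurement. Among the measured compounds shown here, no step between the two measured compounds is drawn, since they differ in more than one place.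

Compound 3, `OC[C@H]1O[C@@H](n2cnc3c(CSc4ccc(Br)cc4)ncnc32)[C@H](O)[C@@H]1O`, has not yet been measured. Compared with compound 1 it carries a single change: ((4-bromophenyl)sulfanyl)methyl in place of pentylamino on an aromatic carbon. For this change the account expects a move to a lower number, from compound 1 to compound 3, of a size beyond the scatter, namely a 14-fold lower number from compound 1 to compound 3 (1.13 log units; beyond the scatter). On that basis compound 3 is estimated to give 1000 nM in this assay, with a range from 150 nM to 8000 nM.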

Compound 3, half-maximal inhibitory concentration: 178 nM
Compound 3: middle estimate off by 5.6-fold (0.75 log units), on the high side, within the range that was stated.
By their numbers in this assay, from the lowest: compound 3; then compound 1; then compound 2.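

In this assay, the aromatic carbon of the shared core that carries pentylamino in compound 1 proves able to take a quite different substituent, and ((4-bromophenyl)sulfanyl)methyl there brings a 76-fold lower number from compound 1 to compound 3 (1.88 log units; beyond the scatter) as a large gain. The change swaps several things at once, since the entering group brings a six-membered aromatic ring, a sulfur and a bromine and has no hydrogen-bond donor, so this one step cannot assign the gain to any one of them. No measurement at hand accounts for the size of the step.

The compounds shown leave open how much the bromine and the sulfur each contribute, which a chloro group on the ring or an oxygen in place of the sulfur would test. They also leave open how a benzylamino group or a shorter alkylamino chain would fare at this carbon.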